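Swapping the Acetyl Group on a Fully Consumed Compound

The source may report more compounds than this note shows. Statements on the series, on what has been measured and on what is new or still open speak of the compounds shown alone.

Values so far in an ADME assay on cells (Hepatocyte, Mus musculus) for metabolic stability, with a stated time of 30 min; a lower number here means that less of the compound is left, a higher number that more of the compound is left

Compound 1 `CC(=O)OC1CCC(CN2CCN(c3cc(=O)c4cc(C(F)(F)F)cc([N+](=O)[O-])c4s3)CC2)CC1` gives 0%
Compound 2 `Nc1cc(C(F)(F)F)cc2c(=O)cc(N3CCN(CC4CCC(O)CC4)CC3)sc12` gives 60%
Compound 3 `Nc1cc(C(F)(F)F)cc2c(=O)cc(N3CCN(CC4CCCCC4)CC3)sc12` gives 69.4%

Compound 1 stands lowest of the three, beyond the scatter from both of the others. Compound 4 `COc1ccc(C(=O)OC2CCC(CN3CCN(c4cc(=O)c5cc(C(F)(F)F)cc([N+](=O)[O-])c5s4)CC3)CC2)cc1` keeps the core of compound 1 and carries one change, (4-methoxyphenyl in place of methyl on a carbonyl carbon), with 4-methoxyphenyl in place of methyl on a carbonyl carbon.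

For the measured compounds named here, only one measured step is available, a number 9.4 percentage points higher from compound 2 to compound 3 (within the scatter), and it lies within the scatter. That step is hydrogen in place of hydroxy on a saturated ring carbon, in a pair that has a different core from compound 1 and lacks this carbonyl group, so it bears only weakly on the change. The data do not show which feature of compound 1 goes with its low number. With the core unchanged, only a modest rise is expected, and the expected step is a number 8 percentage points higher from compound 1 to compound 4 (within the scatter) in this assay. From the compounds shown here alone, for compound 4 the estimate is 8%, with an expected range from 0% to 30% and the outcome still open.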

Compound 4, percent of the compound remaining: 31%
Estimate against measurement, compound 4: 23 percentage points below, outside the stated range (above it).
By their numbers in this assay, from the lowest: compound 1; then compound 4; then compounds 2 and 3 (each within the scatter of the next).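

In this assay, the group on this carbonyl carbon proves able to move the number with the core of compound 1 held fixed: 4-methoxyphenyl in place of methyl gives a number 31 percentage points higher from compound 1 to compound 4 (beyond the scatter), a large step. The low value of compound 1 therefore does not follow from its core alone, something the earlier step, made at another place on a different core, could not show. No measured evidence bears on why the number rises.

The compounds shown do not separate the part played by the aromatic ring from that of its methoxy group, a question that a plain benzoyl group would address. They also leave open how the number would respond to an amide in place of the ester link at this position.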